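The source may hold more compounds than are shown below. What is called first, only, known or untested is meant among the compounds shown, and "the series" means these compounds.

Measured so far:
compound 1 `Oc1c(C(Nc2ccccn2)c2c(Cl)cccc2Cl)ccc2cccnc12` — 1890 nM
compound 2 `Oc1c(C(Nc2ccccn2)c2ccc(Cl)cc2)ccc2cccnc12` — 170 nM

Compound 2 gives the lowest of the two numbers in an assay for inhibition of protein disulfide-isomerase (Homo sapiens), with a stated time of 1 h; a lower number here means a stronger inhibitor, a higher number a weaker inhibitor; the nearest is compound 1, and the step of an 11-fold lower number from compound 1 to compound 2 (1.05 log units; beyond the scatter) is the only one recorded. Compound 3 `Cc1cc(C)c(C(Nc2ccccn2)c2ccc3cccnc3c2O)c(C)c1` differs from compound 2 by 2,4,6-trimethylphenyl in place of 4-chlorophenyl on a saturated chain carbon bound to an aromatic carbon and a nitrogen on an aromatic ring. Within the data shown here, only that one step bears on the change: it shows that the group on this carbon moves the number a great deal, and compound 3 carries a 2,4,6-trimethylphenyl whose name recalls the 2,6-dichlorophenyl of compound 1 more than the 4-chlorophenyl of compound 2. Compound 3 is therefore expected to give a higher number, a 7.1-fold higher number from compound 2 to compound 3 (0.85 log units; beyond the scatter), estimated at 1200 nM with a range from 300 nM to 4500 nM.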

Compound 3, half-maximal inhibitory concentration: 190 nM
Compound 3: middle estimate off by 6.3-fold (0.80 log units), on the high side, outside the stated range (below it).
By their numbers in this assay, from the lowest: compounds 2 and 3 (each within the scatter of the next); then compound 1.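

In this assay, 2,4,6-trimethylphenyl in place of 4-chlorophenyl gives a 1.1-fold higher number from compound 2 to compound 3 (0.05 log units; within the scatter), so these two groups are not told apart on this saturated chain carbon, although they differ in what they carry. In place of 2,6-dichlorophenyl, the same group gives a 9.9-fold lower number from compound 1 to compound 3 (1.00 log units; beyond the scatter), so the higher number of compound 1 does not follow from the numbering that the two names share. Nothing measured here gives a reason for this.

From the compounds shown here alone, whether a phenyl with no substituent, or one carrying an amine or a carboxylic acid, would on this carbon sit with compound 2 and compound 3 or with compound 1 stays open.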